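This account rests on a few compounds, and the source may have more. Where it says the series, first, only, none or still open, it means among the compounds named here.

Measured so far in an ADME assay on Huh7.5.1 cells (Homo sapiens) for cytotoxicity, read by ATP content, with a stated time of 48 h; a lower number here means that less compound is tolerated, a higher number that more compound is tolerated:
- compound 1 `Cc1ccccc1-c1nc(CN2CCC(C(=O)NCCCN3CCC(C(C)C)CC3)CC2)c(C)o1`: 4280 nM
- compound 2 `Cc1ccccc1-c1nc(CN2CCC(C(=O)NCCCN3[C@H](C)CCC[C@@H]3C)CC2)c(C)o1`: 21300 nM
- compound 3 `Cc1ccccc1-c1nc(CN2CCC(C(=O)NCCCN3CCCC(CC(C)C)C3)CC2)c(C)o1`: 4640 nM

Compound 1 shares the low end of these numbers with compound 3, as a 1.1-fold higher number from compound 1 to compound 3 (0.04 log units; within the scatter) shows. Compound 2 stands clearly higher, with a 5.0-fold higher number from compound 1 to compound 2 (0.70 log units; beyond the scatter) and a 4.6-fold lower number from compound 2 to compound 3 (0.66 log units; beyond the scatter).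

Compound 4 `Cc1cccc(Cl)c1-c1nc(CN2CCC(C(=O)NCCCN3CCC(C(C)C)CC3)CC2)c(C)o1` differs from compound 1 by one change: chloro in place of hydrogen on an aromatic carbon. This turns 2-methylphenyl into 2-chloro-6-methylphenyl.

Among the compounds with values here, none of the measured steps makes this change. All three swap the group on the saturated chain and leave the 2-methylphenyl group untouched, so they bear on it only indirectly. They show how far this assay can move in this series, from a 1.1-fold higher number from compound 1 to compound 3 (0.04 log units; within the scatter) up to a 5.0-fold higher number from compound 1 to compound 2 (0.70 log units; beyond the scatter). With no measured change on the aromatic ring, no clear shift in either direction is expected, only a slight drop at most. The expected change is a 1.1-fold lower number from compound 1 to compound 4 (0.05 log units; within the scatter).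

For compound 4 the estimated value is 3800 nM, with an expected range from 1900 nM to 8000 nM.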

Compound 4, half-maximal cytotoxic concentration: 4910 nM
Estimate against measurement, compound 4: 1.3-fold (0.11 log units) below, within the range that was stated.
By their numbers in this assay, from the lowest: compounds 1, 3 and 4 (each within the scatter of the next); then compound 2.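

Unlike the earlier steps, which all swap the group on the saturated chain, this one changes an aromatic carbon of the six-membered aromatic ring: in this assay, turning 2-methylphenyl into 2-chloro-6-methylphenyl gives a 1.1-fold higher number from compound 1 to compound 4 (0.06 log units; within the scatter). At this position, then, chloro in place of hydrogen leaves the number within the scatter, whereas a chain swap can move it beyond the scatter, as a 5.0-fold higher number from compound 1 to compound 2 (0.70 log units; beyond the scatter) shows. Nothing measured here offers an explanation for this result.

One small group at one position says little about the position as a whole, so a carboxylic acid, an amine or a methoxy group there could give a different number. On these data alone, it also remains open whether chloro would leave the number as little changed alongside the 2,6-dimethylpiperidin-1-yl group of compound 2.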